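Trifluoromethyl in place of methoxy on compound 3

The source may report more compounds than this note shows. Statements on the series, on what has been measured and on what is new or still open speak of the compounds shown alone.

The three measured compounds share one scaffold and differ at the benzylic ring. In an ADME assay on RAW264.7 cells (Mus musculus) for cytotoxicity, read by MTT assay, with a stated time of 72 h, tested at 50 uM (on this read-out lower numbers stand for less inhibition and higher numbers for more inhibition at the one concentration tested (going by the name of the read-out)), compound 1 `CCOC(=O)c1sc(-c2ccccc2)nc1N1CCC(NCc2ccc(C(F)(F)F)cc2)CC1` gives 22.7%, compound 2 `CCOC(=O)c1sc(-c2ccccn2)nc1N1CCC(NCc2ccccc2)CC1` gives 14.6%, and compound 3 `CCOC(=O)c1sc(-c2ccccn2)nc1N1CCC(NCc2ccc(OC)cc2)CC1` gives 4.62%. Compound 3 thus has the lowest of the three numbers; its gap to compound 2 is within the scatter, a number 10 percentage points lower from compound 2 to compound 3 (within the scatter), while its gap to compound 1 is beyond it.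

Compound 4 `CCOC(=O)c1sc(-c2ccccn2)nc1N1CCC(NCc2ccc(C(F)(F)F)cc2)CC1` is compound 3 with one change: trifluoromethyl in place of methoxy on an aromatic carbon. Among the measured compounds shown here, no measured step shows exactly this exchange. For the measured compounds named here, the only step near it, a number 10 percentage points lower from compound 2 to compound 3 (within the scatter), was small and within the scatter. Compound 1 carries the same trifluoromethyl group on a different core and reads higher than compound 3, so a move upward is plausible but weakly supported. The expected step in this assay is a number 10.4 percentage points higher from compound 3 to compound 4 (beyond the scatter), a modest rise. For compound 4 the estimate is 15%, with a range from 3% to 30%.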

Compound 4, a percentage reported as inhibition, at one concentration (the size of the read-out at that concentration, not a potency): 14.6%
Compound 4: the middle estimate sits 0.4 percentage points above what was measured; low and high end bracket the measured number.
By their numbers in this assay, from the lowest: compounds 3, 2, 4 and 1 (each within the scatter of the next, the first and the last beyond it).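

In this assay, this aromatic carbon now has hydrogen, methoxy and trifluoromethyl to compare on the same core, and the trifluoromethyl compound cannot be told apart from either of the others: the readings show a number 10 percentage points higher from compound 3 to compound 4 (within the scatter) and no change at the digits printed from compound 2 to compound 4 (within the scatter). The other single change, pyridin-2-yl in place of phenyl with trifluoromethyl kept, gives a number 8.1 percentage points lower from compound 1 to compound 4 (within the scatter), so at this concentration none of the new one-place comparisons separates two compounds. The data offer no measured basis for explaining these readings.

On these data alone, whether an amine or a carboxylic acid on this aromatic carbon would give a reading clearly apart from these compounds remains open. So does the outcome for trifluoromethyl on a different carbon of the same ring.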